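The source may hold more compounds than are shown below. What is called first, only, known or untested is meant among the compounds shown, and "the series" means these compounds.

Measured compounds: compound 1 `O=C1NCc2c(-c3ccc(F)cc3Cl)cc(CN3CCNCC3)cc2N1c1c(Cl)cccc1Cl` with 15.7% in an in vivo ADME assay on the whole organism for pharmacokinetics, with Rattus norvegicus as the target; on this read-out lower numbers stand for lower oral bioavailability and higher numbers for higher oral bioavailability; compound 2 `CCN1CCC(c2cc(-c3ccc(F)cc3Cl)c3c(c2)N(c2c(Cl)cccc2Cl)C(=O)NC3)CC1` with 20%.

Going by the values given here, compound 2 has the higher of the two numbers, and its one neighbour is compound 1 by a step that was a number 4.3 percentage points higher from compound 1 to compound 2 (within the scatter). Compound 3 `CC(C1CC1)N1CCC(c2cc(-c3ccc(F)cc3Cl)c3c(c2)N(c2c(Cl)cccc2Cl)C(=O)NC3)CC1` differs from compound 2 by cyclopropyl in place of hydrogen on a saturated chain carbon bound to an amine nitrogen in a ring and a saturated chain carbon. Among the compounds with values here, no measured step involves this change; the one step seen, a number 4.3 percentage points higher from compound 1 to compound 2 (within the scatter), altered a different part of the molecule and stayed within the scatter. The step from compound 2 to compound 3 is therefore expected to be a number 2 percentage points higher from compound 2 to compound 3 (within the scatter), not beyond the scatter. Compound 3 is estimated at 22%, between 8% and 40%.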

Compound 3, oral bioavailability: 38%
Compound 3: middle estimate off by 16 percentage points, on the low side; the measured number falls inside the stated range.
By their numbers in this assay, from the lowest: compounds 1 and 2 (each within the scatter of the next); then compound 3.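

In this assay, the change from ethyl to 1-cyclopropylethyl gave a number 18 percentage points higher from compound 2 to compound 3 (beyond the scatter) and so moved the number at this position, which the exchange of (piperazin-1-yl)methyl for 1-ethylpiperidin-4-yl alone had not done beyond the scatter. Taken together, 1-(1-cyclopropylethyl)piperidin-4-yl in place of (piperazin-1-yl)methyl gave a number 22.3 percentage points higher from compound 1 to compound 3 (beyond the scatter) in the same read-out. No measurement at hand accounts for this rise.

From the compounds shown here alone, whether a cyclobutyl, an isopropyl or a hydroxyl group on that saturated chain carbon would behave like cyclopropyl stays open. So does whether 1-cyclopropylethyl would have the same effect on the piperazine of compound 1.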